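A few compounds are considered here, and "the series" means these few. Any claim that something is new, unique, unknown or untested is made for them only; others in the source may bear on it.

Measured in an ADME assay on cells (Erythrocyte, Homo sapiens), read by spectrophotometry and hemolysis, with a stated time of 24 h; a lower number here means a stronger inhibitor, a higher number a weaker inhibitor:
Compound 1 `O=Cc1cccc(OCc2ccc3no[n+]([O-])c3c2)c1`: 50 uM.
Compound 2 `O=Cc1ccccc1OCc1ccc2no[n+]([O-])c2c1`: > 100 uM.
Compound 3 `C=CCNC(=S)N/N=C/c1ccc(OCc2ccc3no[n+]([O-])c3c2)cc1`: "nd(insoluble)" (no result reported).

Of these three entries, only compound 1 carries a single number, and compound 3 has no result at all. Compound 2 stands at a limit of the assay rather than at a number, and the record says no more than this: the limit of > 100 uM in this assay, at which 1 of the 3 values shown sits. Going by the values given here, no two measured compounds differ in one place alone, so the data hold no measured step to lean on.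

Compound 4 `NC(=O)N/N=C\c1ccccc1OCc1ccc2no[n+]([O-])c2c1` has not yet been measured. It keeps the core of compound 2 and replaces the formyl group on an aromatic carbon with a larger group of 6 heavy atoms: a group of 6 heavy atoms (2 carbon, 3 nitrogen, 1 oxygen; no ring) in place of a group of 2 heavy atoms (1 carbon, 1 oxygen; no ring), on an aromatic carbon. Compound 2 reads > 100 uM, which is a limit, and from that reading no step beyond the scatter is expected in this assay, in either direction. The estimated change is a step that the limit leaves unreadable from compound 2 to compound 4. For compound 4 the expected value is 120 uM, with an estimated range from 50 uM to 300 uM.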

Compound 4, concentration for 50% inhibition: > 100 uM
Compound 4 ended at the assay's limit (the forecaster's own chance of this, stated with the estimate: 70%); the middle value lies beyond the limit too.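

No step can be read from compound 2 to compound 4 in this assay, because each reading is a limit and not a number: the limit of > 100 uM in this assay, at which 2 of the 4 values shown sit.

The compounds shown leave open whether replacing the formyl group with the larger group changes the reading at all.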